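This account rests on a few compounds, and the source may have more. Where it says the series, first, only, none or still open, it means among the compounds named here.

In an ADME assay on PBMC cells (Homo sapiens) for cytotoxicity (a lower number here means that less compound is tolerated, a higher number that more compound is tolerated), compound 1, with the structure `COC(=O)c1cccc(OC(c2ccc(C(F)(F)F)cc2)C2CCN(C(C)CCNC(=O)c3c(Cl)cncc3Cl)CC2)n1`, gives 14600 nM. Within the data shown here, that is the only number in this assay; compound 2, with the structure `CCO/N=C(/c1ccc(Br)cc1)C1CCN(C(C)CCN(C)C(=O)c2c(C)cc[n+]([O-])c2C)CC1`, shows only a limit of > 182000 nM, so compound 1 cannot be placed above or below it. Compound 3, with the structure `CC(CCNC(=O)c1c(Cl)cncc1Cl)N1CCC(C(Oc2cccc(C#N)n2)c2ccc(C(F)(F)F)cc2)CC1`, differs from compound 1 by cyano in place of methoxycarbonyl on an aromatic carbon. Among the measured compounds shown here, no measured pair shows what such a change does here, so the step from compound 1 to compound 3 is expected to stay within the scatter, a 1.0-fold higher number from compound 1 to compound 3 (0.01 log units; within the scatter). Compound 3 is therefore estimated at 15000 nM, between 6000 nM and 40000 nM.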

Compound 3, half-maximal cytotoxic concentration: 15700 nM
For compound 3 the middle estimate is 1.0-fold (0.02 log units) below the measured one; the measured number falls inside the stated range.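

The earlier compounds shown here held no pair that tested this place, and now one does: in this assay, cyano in place of methoxycarbonyl, next to the ring nitrogen, gives a 1.1-fold higher number from compound 1 to compound 3 (0.03 log units; within the scatter). So on this core, going from 4 heavy atoms to 2 at this position leaves the tolerated concentration within the scatter. Nothing shown here gives a reason for this.

On these data alone, whether a carboxylic acid or an amine at the same place would also leave the number within the scatter remains open. So does whether cyano would behave the same way on a different core.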